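A few compounds are considered here, and "the series" means these few. Any claim that something is new, unique, unknown or untested is made for them only; others in the source may bear on it.

In an ADME assay on the whole organism (Rattus norvegicus, strain Fischer 344) for pharmacokinetics, with a stated time of 8 h, at a dose of 3 mg/kg by the oral route (a higher number here means more compound in the circulation at the dose given, a lower number less compound in the circulation), compound 1 `Cc1cc(N2CCC[C@H](COCc3nc(C)no3)C2)c2c(N)c(C(N)=O)sc2n1` gives 722 ng.h/mL and compound 2 `NC(=O)c1sc2nccc(N3CCC[C@H](COCC(=O)N4CCOCC4)C3)c2c1N` gives 756 ng.h/mL. These two values lie within the usual scatter of each other, so compound 2 cannot be set apart from compound 1 on these numbers, although the side chains of the two compounds differ.

Compound 3 `COC[C@H]1CCCN(c2ccnc3sc(C(N)=O)c(N)c23)C1` has not yet been measured. It differs from compound 2 by a single change: hydrogen in place of (morpholin-4-yl)carbonyl on a saturated chain carbon bound to an oxygen on a saturated carbon. This places hydrogen in place of (morpholin-4-yl)carbonyl on a saturated chain carbon bound to an oxygen on a saturated carbon, so that ((morpholin-4-yl)carbonyl)methoxy becomes methoxy.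

Going by the values given here, no measured pair of compounds shows this change, so the data give no direct guide to its size or direction. With only the two close values to go on, no step beyond the scatter is expected in this assay. The estimated change is small, a 1.3-fold lower number from compound 2 to compound 3 (0.10 log units; within the scatter), and the uncertainty around it is wide. For compound 3 the expected value is 600 ng.h/mL, within an estimated range from 180 ng.h/mL to 2000 ng.h/mL.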

Compound 3, area under the concentration-time curve: 227 ng.h/mL
For compound 3 the middle estimate is 2.6-fold (0.42 log units) above the measured one; the range from low to high includes it.
By their numbers in this assay, from the lowest: compound 3; then compounds 1 and 2 (each within the scatter of the next).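

In this assay, hydrogen in place of (morpholin-4-yl)carbonyl gives a 3.3-fold lower number from compound 2 to compound 3 (0.52 log units; beyond the scatter), the first change at a single place that can be read among these compounds. The two earlier compounds differ in their side chains yet stand within the scatter of each other, which might have suggested that the end of this chain matters little; the new step shows that, at least for this pair, ((morpholin-4-yl)carbonyl)methoxy and methoxy on the shared core cannot be exchanged without a real difference in the number. The data offer no measurement that accounts for this difference.

As far as these compounds go, what remains open is which part of the departing group carries the step, as a single pair cannot separate the morpholine ring from the carbonyl or from the chain that holds them, and a dimethylamino carbonyl, a carboxylic acid or a longer alkyl ether at the same place would each bear on that question. From the compounds shown here alone, it also remains open whether the same change would give a step of similar size and direction on a core carrying the methyl group of compound 1.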